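Removing One Methoxy Group on a Pyrazolyl Chalcone Series

This account rests on a few compounds, and the source may have more. Where it says the series, first, only, none or still open, it means among the compounds named here.

Compound 1 `COc1ccc(-c2cc(/C=C/C(=O)c3ccc(N)cc3)[nH]n2)cc1` gives -89% in a functional assay on UACC-62 cells (Homo sapiens) for cytotoxicity, read by sulforhodamine B assay, with a stated time of 48 h, tested at 10 uM; a lower number here means a stronger effect, a higher number a weaker effect of the compound at the concentration tested. Compound 2 `COc1ccc(-c2cc(/C=C/C(=O)c3ccc(N)cc3)[nH]n2)cc1OC` gives 3% in this assay, and the step of a number 92 percentage points lower from compound 2 to compound 1 (beyond the scatter) is hydrogen in place of methoxy on an aromatic carbon. Compound 3 `COc1cc(C(=O)/C=C/c2cc(-c3cc(OC)c(OC)c(OC)c3)n[nH]2)cc(OC)c1OC` gives -69%; the difference between the core of compound 3 and the core of compound 2 is not broken down here. Compound 4 `COc1ccc(-c2cc(/C=C/C(=O)c3cc(OC)c(OC)c(OC)c3)[nH]n2)cc1OC` is not yet measured; it differs from compound 3 by hydrogen in place of methoxy on an aromatic carbon, the same kind of change as from compound 2 to compound 1, though here the place is also meta to a methoxy group. Compound 4 is expected to give a step of a number 13 percentage points lower from compound 3 to compound 4 (beyond the scatter), a smaller step than the earlier one, because compound 3 already shows -69%. Compound 4 is therefore estimated at -82%, between -100% and -35%.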

Compound 4, a percentage reported as activity, at one concentration (the size of the read-out at that concentration, not a potency): -61%
Compound 4: the middle estimate sits 21 percentage points below what was measured; the measured number falls inside the stated range.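

On the second core, hydrogen in place of methoxy gives a number 8 percentage points higher from compound 3 to compound 4 (within the scatter) in this assay, so the large step seen on the first core is not repeated. The outcome of this change therefore depends on the core that carries it, and the two steps differ clearly: the same change on two cores in this assay, a number 92 percentage points lower (beyond the scatter) from compound 2 to compound 1 and a number 8 percentage points higher (within the scatter) from compound 3 to compound 4, 100 percentage points apart, beyond the scatter of two such steps. Within the data shown here, with only two pairs, this does not show which difference between the cores is responsible, nor how the change would behave on any further core.

The compounds shown leave open how a hydroxy group, a chlorine atom or an ethoxy chain at the same place would compare with methoxy and hydrogen. They also leave open how either would behave on each of the two cores.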